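The source may hold more compounds than are shown below. What is called first, only, known or untested is meant among the compounds shown, and "the series" means these compounds.

Series notes. In a functional assay on NCI-H522 cells (Homo sapiens) for inhibition, read by sulforhodamine B assay, with a stated time of 48 h (a lower number here means that less compound is tolerated, a higher number that more compound is tolerated), compound 1 `CCOC(=O)[C@H](CCC(=O)O)NC(=O)c1ccc(Sc2nc3cc(N)cc(N)c3nc2-c2ccccc2)cc1` gives only a limit, < 100000 nM. Compound 2 `Nc1cc(N)c2nc(-c3ccccc3)c(NCc3ccc(F)cc3)nc2c1` likewise reaches only the limit, < 100000 nM. Compound 3 `COc1ccc(Sc2nc3cc(N)cc(N)c3nc2-c2ccccc2)cc1` stands at the same limit, < 100000 nM. The change a step that the two limits leave unreadable from compound 2 to compound 3 is therefore unreadable. Compound 3 thus has no number of its own; the two further values shown are limits as well, and the limit of < 100000 nM in this assay, at which 3 of the 3 values shown sit, covers all three. Compound 4 `Nc1cc(N)c2nc(-c3ccccc3)c(Oc3ccc(F)cc3)nc2c1` differs from compound 3 by 4-fluorophenoxy in place of (4-methoxyphenyl)sulfanyl on an aromatic carbon. Among the measured compounds shown here, no measured step bears readably on this change, so nothing beyond the scatter is expected in this assay, and compound 4 is expected to sit at the limit too. The estimate for compound 4 is 100000 nM, with range 30000 nM to 300000 nM, meaning an expected step of a number no lower from compound 3 to compound 4 (the limit leaves the size open).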

Compound 4, concentration lethal to 50% of the cells: < 100000 nM
Compound 4 gave a limit, no number; the forecaster's own chance of this, stated with the estimate: 80%; the middle value lies on the limit itself.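

No step among compound 2, compound 3 and compound 4 can be read, as each value is only a limit: the limit of < 100000 nM in this assay, at which 4 of the 4 values shown sit.

The actual values of these compounds, and whether 4-fluorophenoxy, (4-methoxyphenyl)sulfanyl and (4-fluorobenzyl)amino differ at all, stay open.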